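Amide aryl change from compound 2 to compound 3

A few compounds are considered here, and "the series" means these few. Any claim that something is new, unique, unknown or untested is made for them only; others in the source may bear on it.

Compound 1 `CN1CCN(c2ccc(Nc3nc(-c4cccc(NC(=O)c5ccccc5)c4)sc3C(N)=O)cc2)CC1`: in a functional assay on Raji cells (Homo sapiens) for antiproliferative activity, read by CCK-8 assay, with a stated time of 72 h, tested at 40 uM (on this read-out higher numbers stand for more inhibition at the one concentration tested (going by the name of the read-out) and lower numbers for less inhibition), compound 1 gives 91.3%.
Compound 2 `CN1CCN(c2ccc(Nc3nc(-c4cccc(NC(=O)c5ccc(Cl)cc5)c4)sc3C(N)=O)cc2)CC1`: in this assay compound 2 gives 92.6%.

Within the data shown here, compound 2 stands highest of the two numbers measured so far, but its nearest neighbour, compound 1, lies within the scatter of it, so the two are not separated on this read-out. Among the measured compounds shown here, the single measured step, a number 1.3 percentage points higher from compound 1 to compound 2 (within the scatter), concerns chloro in place of hydrogen on an aromatic carbon.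

Compound 3 `CN1CCN(c2ccc(Nc3nc(-c4cccc(NC(=O)c5ccc(C(F)(F)F)cn5)c4)sc3C(N)=O)cc2)CC1` is not yet measured. It differs from compound 2 as follows: 5-(trifluoromethyl)pyridin-2-yl in place of 4-chlorophenyl on a carbonyl carbon. For the measured compounds named here, no measured step covers a change of this kind; the only step recorded, a number 1.3 percentage points higher from compound 1 to compound 2 (within the scatter), kept the 4-chlorophenyl ring in place. Both measured compounds sit near the top of the read-out, and that step was within the scatter, so no step beyond the scatter is expected from compound 2 to compound 3, although a larger structural change leaves more room for a fall than for a rise. Compound 3 is therefore expected to give about 87% in this assay, within 68% to 96%. The expected step is a number 5.6 percentage points lower from compound 2 to compound 3 (within the scatter).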

Compound 3, a percentage reported as inhibition, at one concentration (the size of the read-out at that concentration, not a potency): 84.6%
The estimate for compound 3 lay 2.4 percentage points above the measured number; low and high end bracket the measured number.
By their numbers in this assay, from the lowest: compounds 3, 1 and 2 (each within the scatter of the next).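

Notes on the amide aryl position, on a carbonyl carbon: compound 3 is the first change of the ring itself, not just of a substituent on it. In this assay the replacement of the carbon-only ring by 5-(trifluoromethyl)pyridin-2-yl stays inside the usual scatter against both earlier compounds (a number 8 percentage points lower from compound 2 to compound 3 (within the scatter); a number 6.7 percentage points lower from compound 1 to compound 3 (within the scatter)), so this read-out does not separate the new ring from 4-chlorophenyl or from phenyl. This position therefore accepts a larger group with a ring nitrogen and three fluorines without a step beyond the scatter, and no measurement shown here bears on the reason for these numbers.

The ring nitrogen and the trifluoromethyl group enter together in compound 3, so their separate contributions cannot be told apart, and a reading at one concentration gives no potency for any of the three compounds. Going by these compounds, whether the position would also accept a non-aromatic group on the carbonyl carbon, such as cyclohexyl or a short alkyl chain, or a ring carrying a carboxylic acid, remains open.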